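Switching the azole on the branch carbon of compound 2

A few compounds are considered here, and "the series" means these few. Any claim that something is new, unique, unknown or untested is made for them only; others in the source may bear on it.

Three compounds share a core carrying a fluorinated bicyclic aryl group and a branched side chain that ends in a five-membered heteroaromatic ring. In a functional assay on CHO cells for antagonist activity at prostaglandin E2 receptor EP3 subtype (Homo sapiens), read by cAMP accumulation (a lower number here means a stronger inhibitor, a higher number a weaker inhibitor), compound 1 `CCn1ncc2c(F)cc(-c3ccc(C(CC)(CC)c4nnc[nH]4)c(=O)[nH]3)cc21` gives 29 nM, and compound 3 `CCC(CC)(c1nnc[nH]1)c1ccc(-c2ccc3cccc(F)c3c2)[nH]c1=O` gives 36 nM. Compound 2 `CC(C)C(c1ncco1)c1ccc(-c2ccc3cccc(F)c3c2)[nH]c1=O` gives 64 nM in this assay, the highest of the three numbers: its gap to compound 3 lies within the scatter of the method, whereas compound 1 sits beyond it with the lower number.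

Compound 4 `CC(C)C(c1cnc(N)s1)c1ccc(-c2ccc3cccc(F)c3c2)[nH]c1=O` has not been measured. It differs from compound 2 in one place: 2-amino-1,3-thiazol-5-yl in place of 1,3-oxazol-2-yl on a saturated chain carbon bound to an aromatic carbon and a saturated chain carbon. Among the measured compounds shown here, no pair of measured compounds isolates this kind of exchange, so nothing directly quantifies it.

The expectation is a modest step from compound 2 to compound 4 in this assay, a 1.4-fold lower number from compound 2 to compound 4 (0.15 log units; within the scatter), toward a lower number, but one that could well stay within the scatter. Compound 4 is therefore estimated at 45 nM in this assay, with a range from 15 nM to 150 nM.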

Compound 4, half-maximal inhibitory concentration: 39 nM
For compound 4 the middle estimate is 1.2-fold (0.06 log units) above the measured one, and the stated range covers the measured number.
By their numbers in this assay, from the lowest: compounds 1, 3, 4 and 2 (each within the scatter of the next, the first and the last beyond it).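

In this assay, 2-amino-1,3-thiazol-5-yl in place of 1,3-oxazol-2-yl gives a 1.6-fold lower number from compound 2 to compound 4 (0.22 log units; within the scatter), the first one-place step among these compounds. On a saturated chain carbon bound to an aromatic carbon and a saturated chain carbon, the entering group carries 1 hydrogen-bond donor where the leaving group has 0 and a sulfur in its ring, yet the measured change stays within the scatter, so this position tolerates this exchange without a clear shift in either direction. No measurement at hand accounts for the size of this step.

Going by these compounds, whether the amine or the ring exchange dominates the step remains open, and a 1,3-thiazol-5-yl without the amine would separate the two. Also unresolved is whether the same exchange behaves alike on the core of compound 1, or on the branch carbon bearing two ethyl groups in compound 3.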